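The compounds below may be only part of what the source reports. "The series", "measured", "known", "first", "only" and "open" are said of these compounds alone.

Measured so far:
- compound 1, `Cc1ccc(S(=O)(=O)N[C@H]2CCN(CCCOc3ccc(C(=O)C4CC4)cc3)C2)cc1`: 380 nM
- compound 2, `CC(=O)c1ccc(OCCCN2CC[C@H](NC(=O)c3ccc(C#N)cc3)C2)cc1`: 6100 nM
- compound 3, `CC(=O)c1ccc(OCCCN2CC[C@H](NS(=O)(=O)c3ccc(C#N)cc3)C2)cc1`: 2300 nM

In an assay on isolated protein for binding affinity to histamine H2 receptor (Homo sapiens) (a lower number here means a stronger inhibitor, a higher number a weaker inhibitor), compound 2 gives 6100 nM, the highest of the three numbers and therefore the weakest binder of the set. Where compound 2 carries a carboxamide, a sulfonamide is carried by compound 3, which stands at 2300 nM in this assay, and compound 1 stands at 380 nM. Within the data shown here, both gaps to compound 2 lie beyond the usual scatter, so the ordering is genuine, though no single-point step between the measured compounds has been worked out.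

Compound 4, `CC(=O)c1ccc(OCCCN2CC[C@H](NC(=O)[C@@H](N)CO)C2)cc1`, has not yet been measured. It differs from compound 2 in one place: 1-amino-2-hydroxyethyl in place of 4-cyanophenyl on a carbonyl carbon. The amide linkage on the pyrrolidine and the rest of the shared core are unchanged.

No comparable exchange exists among the measured compounds, so the expected step rests only on the position of compound 2 in this assay. Starting from the weakest point of the set, a move toward a lower number is expected for compound 4, of modest size, a 1.7-fold lower number from compound 2 to compound 4 (0.24 log units; within the scatter), but a result within the scatter of compound 2 cannot be ruled out. Compound 4 is estimated to give 3500 nM in this assay, with a range from 900 nM to 14000 nM.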

Compound 4, inhibition constant: 22000 nM
For compound 4 the middle estimate is 6.3-fold (0.80 log units) below the measured one, and the stated range ends below it.
By their numbers in this assay, from the lowest: compound 1; then compound 3; then compound 2; then compound 4.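

In this assay, among these compounds, 1-amino-2-hydroxyethyl in place of 4-cyanophenyl on a carbonyl carbon gives a 3.6-fold higher number from compound 2 to compound 4 (0.56 log units; beyond the scatter), the only single-place step available. The group on this carbonyl carbon therefore affects the read-out even with the amide linkage on the pyrrolidine and the rest of the shared core unchanged, and here the ring-free group with two hydrogen-bond donors goes with the higher number. No measurement shown bears on the reason for this step.

The single exchange removes the aromatic ring and the nitrile and introduces the amino group, the hydroxyl group and a defined stereocentre all at once, so the compounds shown cannot assign the step to any one of these features, and an unsubstituted phenyl, an aminomethyl or a hydroxymethyl group on the same carbonyl carbon would help to separate them. Also open, going by these compounds, is whether the opposite configuration at the stereocentre of 1-amino-2-hydroxyethyl would give a similar number, and whether the same exchange would have a comparable effect on the sulfonamide of compound 3.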